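The source may report more compounds than this note shows. Statements on the series, on what has been measured and on what is new or still open speak of the compounds shown alone.

Measured in a functional assay on the whole organism (strain Jcl:SD) for inhibition, with Rattus norvegicus as the target, with stated times of 3 min and 3 h, at a dose of 1 mg/kg by the intravenous route; a higher number here means more inhibition at the dose given (going by the name of the read-out), a lower number less inhibition:
compound 1 `CNCc1cc(-c2cccnc2F)n(S(=O)(=O)c2ccoc2)c1` gives 82%
compound 2 `CNCc1cc(-c2cccnc2F)n(S(=O)(=O)c2cccnc2)c1` gives 96%

Among the compounds with values here, compound 2 stands highest of the two numbers in this assay; the only measured step is a number 14 percentage points higher from compound 1 to compound 2 (beyond the scatter), a modest rise for pyridin-3-yl in place of furan-3-yl on a sulfonyl sulfur.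

Compound 3 `CNCc1cc(-c2cnccc2C)n(S(=O)(=O)c2cccnc2)c1` keeps the sulfonyl part of compound 2 and differs from it in 4-methylpyridin-3-yl in place of 2-fluoropyridin-3-yl on an aromatic carbon. Within the data shown here, no measured step touches this position: the one step concerns the sulfonyl sulfur and says nothing about the ring borne on the five-membered ring. With compound 2 already close to the top of the percentage scale, there is little room upward, so the expected step of a number 11 percentage points lower from compound 2 to compound 3 (beyond the scatter) is downward or none beyond the scatter, with wide uncertainty. Compound 3 is therefore estimated at 85%, with a range from 55% to 98%.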

Compound 3, a percentage reported as inhibition, in the whole organism at one dose (the size of the read-out at that dose, not a potency): -54%
Compound 3: middle estimate off by 139 percentage points, on the high side; the whole stated range lies above it.
By their numbers in this assay, from the lowest: compound 3; then compound 1; then compound 2.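

In this assay the ring on the aromatic carbon next to the ring nitrogen proves far more sensitive than the sulfonyl sulfur: the change to 4-methylpyridin-3-yl gives a number 150 percentage points lower from compound 2 to compound 3 (beyond the scatter), a large step, against the modest a number 14 percentage points higher from compound 1 to compound 2 (beyond the scatter). The two groups match in heavy-atom count, in hydrogen-bond acceptors and in ring type, so these counts do not separate them, yet compound 3 reads -54%, a negative number on a read-out of inhibition. Nothing available accounts for this collapse.

From the compounds shown here alone, the change swaps the substituent and its place on the pyridine at once, so it remains open whether the loss follows from losing the fluorine or from gaining the methyl. 2-Methylpyridin-3-yl and 4-fluoropyridin-3-yl on the same carbon would separate these two readings.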